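A few compounds are considered here, and "the series" means these few. Any claim that something is new, unique, unknown or untested is made for them only; others in the source may bear on it.

The shared core is carried by compound 1 `COC(c1cc(Cl)c2c(c1Cl)C(=O)N(Cc1c(C)cc(C)[nH]c1=O)CC2)C1CCOC1`, compound 2 `COC(c1cc(Cl)c2c(c1Cl)C(=O)N(Cc1c(C)cc(C)[nH]c1=O)CC2)C1CCS(=O)(=O)CC1`, compound 3 `Cc1cc(C)c(CN2CCc3c(Cl)cc([C@H](CO)[C@@H]4CCCO4)c(Cl)c3C2=O)c(=O)[nH]1` and the not yet measured compound 4 `Cc1cc(C)c(CN2CCc3c(Cl)cc([C@@H](CO)[C@@H]4CCCO4)c(Cl)c3C2=O)c(=O)[nH]1`. In an assay on cells for inhibition of histone-lysine N-methyltransferase EZH2 (Homo sapiens), read by ELISA, with a stated time of 72 h (a higher number here means a weaker inhibitor, a lower number a stronger inhibitor), compound 1 gives 1100 nM; 494 nM; 47 nM; 7 nM (4 entries), a spread across its entries that is wider than repeat scatter, as the several entries of compound 1 show (the several entries of compound 1 in this assay, 1100 nM; 494 nM; 47 nM; 7 nM (4 entries)). In this assay compound 2 gives 430 nM; 18 nM (2 entries), again with entries that lie apart (the several entries of compound 2 in this assay, 430 nM; 18 nM (2 entries)). For the measured compounds named here, compound 3 gives 41 nM in this assay, the only single number among its entries; two further entries yield no single number.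

Compound 4 differs from compound 3 only in configuration: the two compounds have the same atoms and bonds and differ only in configuration as drawn: 1 of 2 stereo elements differ; a stereocentre at a saturated chain carbon is drawn R in compound 3 and S in compound 4. Going by the values given here, no measured pair shows what such a change at this chain carbon does here, and the data give no direction for it. A diastereomer can sit on either side of its partner, and the spread seen for compound 1 suggests the isomers are not alike. Compound 4 is therefore expected near compound 3, with a wide band that admits a step of a 1.7-fold higher number from compound 3 to compound 4 (0.23 log units; within the scatter) in either direction, giving an estimated 70 nM (range 8 nM to 600 nM).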

Compound 4, half-maximal inhibitory concentration: 1570 nM
The estimate for compound 4 lay 22-fold (1.35 log units) below the measured number; measured number above the stated range.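

In this assay, the change of configuration at the saturated chain carbon gives a 38-fold higher number from compound 3 to compound 4 (1.58 log units; beyond the scatter), the first measured direction for this position. For the compounds shown here, the R configuration as drawn in compound 3 goes with the lower number, so this stereocentre is not a neutral feature of the series, as no earlier pair could show. The gap can be laid to this stereocentre alone, because no atom or bond changes: the fact that compounds 3 and 4 differ only in the configuration as drawn.

From the compounds shown here alone, whether the spread in compound 1 reflects separate isomers stays open: the several entries of compound 1 in this assay, 1100 nM; 494 nM; 47 nM; 7 nM (4 entries). Also open, going by these compounds, are what the second stereo element, drawn alike in compound 3 and compound 4, contributes, and whether the same preference for R would hold with an amine or a carboxylic acid on this chain carbon.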